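Compound 1 to compound 4: replacing the cyano group

A few compounds are considered here, and "the series" means these few. Any claim that something is new, unique, unknown or untested is made for them only; others in the source may bear on it.

Compound 1 (`Cc1cc(C#N)cc(C)c1Oc1ccc(N)c(Nc2ccc(C#N)cc2)n1`) is the reference point in an ADME assay on TZM cells (Homo sapiens) for cytotoxicity, read by XTT assay, with a stated time of 4 days; on this read-out lower numbers stand for higher toxicity in this test and higher numbers for lower toxicity in this test. Among the compounds with values here, compound 1 gives 8980 nM, the only true number among the three values shown. Compound 2 (`Cc1cc(/C=C/C#N)cc(C)c1Oc1ccc([N+](=O)[O-])c(Nc2ccc(C#N)cc2)c1`) reads > 48700 nM, which is a limit of the assay. Compound 3 (`Cc1cc(/C=C/C#N)cc(C)c1Oc1cc(Nc2ccc(C#N)cc2)c([N+](=O)[O-])cc1[N+](=O)[O-]`) reads > 43900 nM, which is also a limit.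

Compound 4 (`Cc1cc(C#CC2CC2)cc(C)c1Oc1ccc(N)c(Nc2ccc(C#N)cc2)n1`) has not yet been measured. It differs from compound 1 as follows: 2-cyclopropylethynyl in place of cyano on an aromatic carbon. The new group sits on the same aromatic carbon, meta to two methyl groups and para to a large group.

Within the data shown here, the only measured step is a step that the two limits leave unreadable from compound 2 to compound 3, with nitro in place of hydrogen on an aromatic carbon. It has no readable size and involves a different change. Among the measured compounds shown here, compound 2 and compound 3 also differ from compound 1 in more than one place, so no measured step bears directly on this exchange.

With compound 1 at 8980 nM as the only anchor, no shift beyond the scatter is expected in this assay, and neither direction is favoured. The expected size is a 1.0-fold higher number from compound 1 to compound 4 (0.00 log units; within the scatter), held with wide margins. The estimated value for compound 4 is 9000 nM, with an expected range of 3000 nM to 30000 nM.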

Compound 4, half-maximal cytotoxic concentration: 7450 nM
The estimate for compound 4 lay 1.2-fold (0.08 log units) above the measured number, and the stated range covers the measured number.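

At the aromatic carbon meta to two methyl groups, this assay now gives a readable step for 2-cyclopropylethynyl in place of cyano: a 1.2-fold lower number from compound 1 to compound 4 (0.08 log units; within the scatter). The exchange removes the nitrile and brings in a triple bond carrying a three-membered carbon ring, yet the read-out does not separate the two groups at this one position on the core of compound 1. Within the data shown here, the earlier compounds could not show this, since none of their pairs changes this position and the only step among them cannot be read.

Nothing among the measurements shown bears on why the two groups read alike here. Still open, from the compounds shown here alone, is whether an amine, a carboxylic acid or a longer alkyl chain on the same aromatic carbon would also stay within the scatter of compound 1, and whether 2-cyclopropylethynyl in place of cyano would read the same way on a core other than that of compound 1.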